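Replacing the pyridin-3-yl of compound 1 with benzamido

The source may report more compounds than this note shows. Statements on the series, on what has been measured and on what is new or still open speak of the compounds shown alone.

Measured compounds:
- compound 1 `O=C(O)c1ccc2noc(-c3ccc(-c4cccnc4)cc3)c2c1` gives 54 nM in an assay for inhibition of inositol hexakisphosphate kinase 2 (Homo sapiens), read by colorimetric assay, coupled enzyme assay and malachite green, with a stated time of 120 min, in the presence of a further agent that is not named here; on this read-out lower numbers stand for stronger inhibition and higher numbers for weaker inhibition
- compound 2 `CC(C)NC(=O)c1ccc(-c2onc3ccc(C(=O)O)cc23)cc1` gives 350 nM in this assay
- compound 3 `O=C1CCC(C(=O)Nc2ccc(-c3onc4ccc(C(=O)O)cc34)cc2)CN1` gives 2390 nM in this assay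

Compound 1 stands lowest of the three numbers in this assay. Its nearest neighbour is compound 2, and compound 3 lies furthest away with its far higher value. Compound 4 `O=C(O)c1ccc2noc(-c3ccc(NC(=O)c4ccccc4)cc3)c2c1` has not been measured; it differs from compound 1 in one place: benzamido in place of pyridin-3-yl on an aromatic carbon.

For the measured compounds named here, one measured step bears on this change. Exchanging the pyridin-3-yl for a carbamoyl-type group gave a 6.5-fold higher number from compound 1 to compound 2 (0.81 log units; beyond the scatter). Going by the values given here, compound 3, whose own amido-type group sits in the same place, shows a still higher number than compound 1, though no single step links those two. Both observations point the same way: substituting the pyridin-3-yl here has so far raised the number beyond the scatter, and benzamido is expected to do the same. Compound 4 is therefore estimated at 600 nM, within 150 nM to 2500 nM, an expected step of an 11-fold higher number from compound 1 to compound 4 (1.05 log units; beyond the scatter).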

Compound 4, half-maximal inhibitory concentration: 580 nM
Compound 4: middle estimate off by 1.0-fold (0.01 log units), on the high side; low and high end bracket the measured number.
By their numbers in this assay, from the lowest: compound 1; then compounds 2 and 4 (each within the scatter of the next); then compound 3.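

In this assay, benzamido keeps a six-membered aromatic ring on this aromatic carbon, yet the change still gives an 11-fold higher number from compound 1 to compound 4 (1.03 log units; beyond the scatter) and so is a large step, which shows that carrying such a ring here does not by itself preserve the low number of compound 1. Benzamido and isopropylcarbamoyl cannot be told apart at this position, with a 1.7-fold higher number from compound 2 to compound 4 (0.22 log units; within the scatter) lying within the scatter. The group on the amide carbonyl carbon does matter, since the six-membered ring of carbon only in place of the non-aromatic ring with one hetero atom gives a 4.1-fold lower number from compound 3 to compound 4 (0.61 log units; beyond the scatter) beyond the scatter.

The compounds shown leave open whether a plain phenyl, a pyridin-4-yl or a simple amine on this carbon would stay close to compound 1. Nothing measured here accounts for any of these differences.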